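A few compounds are considered here, and "the series" means these few. Any claim that something is new, unique, unknown or untested is made for them only; others in the source may bear on it.

Measured so far:
Compound 1 `COC(=O)c1[nH]c2ccccc2c1C(=O)c1cc(OC)c(OC)c(OC)c1N`: 2380 nM
Compound 2 `COC(=O)c1[nH]c2ccc(Cl)cc2c1C(=O)c1cc(OC)c(OC)c(OC)c1N`: 2140 nM
Compound 3 `COc1cc(Cc2c[nH]c3ccccc23)c(N)c(OC)c1OC`: > 100000 nM

In a functional assay on HT-29 cells (Homo sapiens) for cytotoxicity, read by sulforhodamine B assay, with a stated time of 48 h (a higher number here means a weaker inhibitor of growth, a lower number a stronger inhibitor of growth), compound 1 gives 2380 nM. Compound 2 carries the change chloro in place of hydrogen on an aromatic carbon on the core of compound 1; in this assay compound 2 gives 2140 nM, a step of a 1.1-fold lower number from compound 1 to compound 2 (0.05 log units; within the scatter). Within the data shown here, for compound 3 the value in this assay is a limit of the assay and not a number: compound 3 gives > 100000 nM, and it is the one value sitting at the limit of > 100000 nM in this assay, at which 1 of the 3 values shown sits. The difference between the core of compound 3 and the core of compound 1 is not broken down here.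

Compound 4 `COc1cc(Cc2c[nH]c3ccc(Cl)cc23)c(N)c(OC)c1OC` is not yet measured in this assay. It carries chloro in place of hydrogen on an aromatic carbon on the core of compound 3, the same change that was made from compound 1 to compound 2. That change moved the number by a 1.1-fold lower number from compound 1 to compound 2 (0.05 log units; within the scatter), a step inside the scatter, so the step from compound 3 to compound 4 is expected to be likewise small, a number no higher from compound 3 to compound 4 (the limit leaves the size open), and compound 4 is expected to remain at the limit where compound 3 sits. Compound 4 is estimated at 100000 nM, between 30000 nM and 300000 nM.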

Compound 4, concentration for 50% growth inhibition: "not active" (no number reported)
For compound 4 the study gives words and no number; the estimate stays without a comparison.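

In this assay compound 3 gives > 100000 nM, a limit of the assay and not a number. Among these compounds, compound 4 is reported only in words, as not active, so no step from compound 3 to compound 4 can be read. The compounds shown leave open whether chloro in place of hydrogen changes growth inhibition on the core of compound 3.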